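Replacing Chloro with Methoxymethyl on an Aromatic Carbon

A few compounds are considered here, and "the series" means these few. Any claim that something is new, unique, unknown or untested is made for them only; others in the source may bear on it.

In a functional assay on the whole organism with Rattus norvegicus as the target (on this read-out higher numbers stand for an effect only at larger amounts of compound and lower numbers for an effect already at smaller amounts), compound 1 `CCOCCOC(=O)C(=O)Nc1nc(-c2cc(Cl)no2)cs1` gives 6 mg/kg, the higher of the two numbers available, while compound 2 `CCOC(=O)C(=O)Nc1nc(-c2cc(C)no2)cs1` gives 0.2 mg/kg, a gap beyond the scatter. Compound 3 `CCOCCOC(=O)C(=O)Nc1nc(-c2cc(COC)no2)cs1` departs from compound 1 in one place: methoxymethyl in place of chloro on an aromatic carbon. Going by the values given here, no measured step isolates this change: compound 1 and compound 2 differ in more than one place. A moderate shift towards a lower number in this assay is expected, the estimated step being a 3.0-fold lower number from compound 1 to compound 3 (0.48 log units; beyond the scatter). For compound 3 the expected value is 2 mg/kg, with an estimated range of 0.3 mg/kg to 10 mg/kg.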

Compound 3, dose for half-maximal effect: 2.4 mg/kg
Compound 3: middle estimate off by 1.2-fold (0.08 log units), on the low side; measured number inside the range.
By their numbers in this assay, from the lowest: compound 2; then compound 3; then compound 1.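

Exchanging chloro for methoxymethyl on this aromatic carbon, next to the ring nitrogen, gives a 2.5-fold lower number from compound 1 to compound 3 (0.40 log units; beyond the scatter) in this assay. Going by these compounds alone, this is the first reading at this position with the rest of the molecule held constant. It shows that the effect does not depend on chloro here, and that the larger methoxymethyl group moves the number modestly downward. On these data alone, whether an amine, a carboxylic acid or a longer ether chain on the same carbon would shift the number further remains open. Nothing measured here accounts for the step.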